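Aminopiperidine Replaces tert-Butylamine on a Fused Core

This account rests on a few compounds, and the source may have more. Where it says the series, first, only, none or still open, it means among the compounds named here.

Compound 2 `CNc1nc(NC(C)(C)C)c2sc(-c3ccc(C(F)(F)F)cc3)cc2n1` is the only one of the two measured compounds to give an actual number in a physicochemical assay for solubility, at pH 2 (a lower number here means a less soluble compound, a higher number a more soluble compound), where compound 2 gives 1.6 ug/mL. Compound 1 `CNc1nc(N)c2sc(-c3ccc(C(F)(F)F)cc3)cc2n1` instead reaches a limit of the assay, giving > 100 ug/mL in this assay. For the measured compounds named here, the single measured step, an at least 62-fold lower number from compound 1 to compound 2 (1.79 log units; beyond the scatter), therefore cannot be fully sized, since one end sits at the limit of > 100 ug/mL in this assay, at which 1 of the 2 values shown sits.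

Compound 3 `CNc1nc(N2CCC(N)CC2)c2sc(-c3ccc(C(F)(F)F)cc3)cc2n1` differs from compound 2 by 4-aminopiperidin-1-yl in place of (tert-butyl)amino on an aromatic carbon. The change removes the tert-butyl whose introduction carried the large drop in an at least 62-fold lower number from compound 1 to compound 2 (1.79 log units; beyond the scatter), and the entering group brings one more nitrogen than leaves. The measured step thus points toward a large rise in this assay, though compound 3 does not simply return to the hydrogen of compound 1. Compound 3 is expected to give 100 ug/mL, estimated between 20 ug/mL and 500 ug/mL, with an expected step of a 63-fold higher number from compound 2 to compound 3 (1.80 log units; beyond the scatter), quite possibly ending at a limit again.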

Compound 3, solubility: > 200 ug/mL
Compound 3 was reported as a limit; the forecaster's own chance of this, stated with the estimate: 50%; middle value at least 2.0-fold (0.30 log units) from the limit.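

With 4-aminopiperidin-1-yl in place of (tert-butyl)amino, on the aromatic carbon next to the ring nitrogen, this assay shows an at least 120-fold higher number from compound 2 to compound 3 (2.09 log units; beyond the scatter). The earlier pair showed only that adding tert-butyl on this nitrogen goes with a low number; this step shows that the position also accepts a ring with more heavy atoms than the group it replaces, and compound 3 still lands at the high end of the values shown. Compound 3 gives a limit of the assay rather than a number, so the step marks only a minimum: the limit of > 200 ug/mL in this assay, at which 1 of the 3 values shown sits.

The step from compound 1 to compound 3 cannot be read, as both values are limits. Going by these compounds, it also stays open whether the rise needs the amine of the 4-aminopiperidin-1-yl group, a question that a plain piperidin-1-yl or a morpholine at this position would address.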